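From pyridin-3-yl to 1,2-thiazol-4-yl

A few compounds are considered here, and "the series" means these few. Any claim that something is new, unique, unknown or untested is made for them only; others in the source may bear on it.

Measured so far in a physicochemical assay for solubility, in phosphate buffer, with a stated time of 18 h, at pH 7; on this read-out lower numbers stand for lower solubility and higher numbers for higher solubility
Compound 1 `Cc1ccc([C@@H]2[C@@H](C(=O)Nc3ccc(F)c(C#N)c3)c3ccccc3C(=O)N2CC(C)C)s1` gives < 1000 nM (a limit)
Compound 2 `CC(C)CN1C(=O)c2ccccc2[C@H](C(=O)Nc2ccc(F)c(C#N)c2)[C@H]1c1ccc(C(N)=O)s1` gives 19000 nM
Compound 3 `CC(C)CN1C(=O)c2ccccc2[C@H](C(=O)Nc2ccc(F)c(C#N)c2)[C@H]1c1cccnc1` gives 55000 nM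

Compound 3 holds the highest true number here, and compound 2 has the nearest value. Compound 4 `CC(C)CN1C(=O)c2ccccc2[C@H](C(=O)Nc2ccc(F)c(C#N)c2)[C@H]1c1cnsc1` carries 1,2-thiazol-4-yl in place of pyridin-3-yl on a saturated ring carbon. Two measured steps changed this same place, and both gave a higher number on arriving at pyridin-3-yl: a large one (an at least 55-fold higher number from compound 1 to compound 3 (1.74 log units; beyond the scatter)) and a modest one (a 2.9-fold higher number from compound 2 to compound 3 (0.46 log units; beyond the scatter)). Neither step involved the incoming group, so the size stays uncertain. Leaving pyridin-3-yl is therefore expected to lower the number by a modest step (a 2.2-fold lower number from compound 3 to compound 4 (0.34 log units; beyond the scatter)). For compound 4 the estimate is 25000 nM (expected range 8000 nM to 60000 nM).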

Compound 4, solubility: 20000 nM
The estimate for compound 4 lay 1.3-fold (0.10 log units) above the measured number; the measured number falls inside the stated range.
By their numbers in this assay, from the lowest: compounds 2 and 4 (each within the scatter of the next); then compound 3. At a limit, below all of these: compound 1.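

In this assay, 1,2-thiazol-4-yl does not hold the level of pyridin-3-yl, with a 2.8-fold lower number from compound 3 to compound 4 (0.44 log units; beyond the scatter). It stands level with 5-carbamoylthiophen-2-yl, with a 1.1-fold higher number from compound 2 to compound 4 (0.02 log units; within the scatter), so a ring without a carbamoyl group reaches the same range here. Against 5-methylthiophen-2-yl the step is large, with an at least 20-fold higher number from compound 1 to compound 4 (1.30 log units; beyond the scatter), and it starts from a limit: the limit of < 1000 nM in this assay, at which 1 of the 4 values shown sits.

Only aromatic rings occupy this position in the compounds shown, so the effect of a saturated amine such as piperidin-4-yl remains open. So does the effect of a carboxylic acid on the 1,2-thiazol-4-yl ring.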